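The compounds below may be only part of what the source reports. "The series", "measured", "known", "first", "only" and "open" are said of these compounds alone.

Measured in an assay on isolated protein for inhibition of tyrosine-protein kinase receptor UFO (Homo sapiens), read by FRET and Z'-LYTE, with a stated time of 1.5 h; on this read-out higher numbers stand for weaker inhibition and lower numbers for stronger inhibition: compound 1 `Cc1c(C(=O)Nc2ccc(Oc3ncnc4[nH]cc(-c5ccccc5)c34)c(F)c2)c(=O)c2cc(Cl)ccc2n1C` gives 1890 nM; compound 2 `CCn1c(C)c(C(=O)Nc2ccc(Oc3ncnc4[nH]cc(-c5ccccc5)c34)c(F)c2)c(=O)c2cc(C)ccc21` gives 150 nM; compound 3 `CCCCn1c(C)c(C(=O)Nc2ccc(Oc3ncnc4[nH]cc(-c5ccccc5)c34)c(F)c2)c(=O)c2cc(C)ccc21` gives 480 nM.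

Compound 1 stands highest of the three numbers on this assay, beyond the scatter from both others. Compound 4 `CCc1ccc2c(c1)c(=O)c(C(=O)Nc1ccc(Oc3ncnc4[nH]cc(-c5ccccc5)c34)c(F)c1)c(C)n2C` differs from compound 1 by ethyl in place of chloro on an aromatic carbon. Among the compounds with values here, the one measured step, a 3.2-fold higher number from compound 2 to compound 3 (0.51 log units; beyond the scatter), concerns the chain on the aromatic nitrogen, not this place, so it does not bear directly. Compounds 2 and 3 carry methyl rather than chloro at that place, but each also differs from compound 1 elsewhere; their lower numbers only hint. For compound 4 a modest downward step a 2.4-fold lower number from compound 1 to compound 4 (0.37 log units; beyond the scatter) is therefore expected, with wide uncertainty. Compound 4 is estimated at 800 nM, range 250 nM to 2500 nM.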

Compound 4, half-maximal inhibitory concentration: 6 nM
Estimate against measurement, compound 4: 130-fold (2.12 log units) above; the whole stated range lies above it.
By their numbers in this assay, from the lowest: compound 4; then compound 2; then compound 3; then compound 1.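

In this assay, ethyl in place of chloro on this aromatic carbon gives a 320-fold lower number from compound 1 to compound 4 (2.50 log units; beyond the scatter), a large step and the first one read at this place. The earlier step concerned only the chain on the aromatic nitrogen, so the strong dependence of the read-out on this substituent is new. No evidence at hand accounts for the size of this step.

Chloro and ethyl alone leave open how a longer chain such as propyl, or an amine, would fare at this place. On these data alone, it also remains open whether the gain carries over when a butyl chain sits on the aromatic nitrogen.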